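A few compounds are considered here, and "the series" means these few. Any claim that something is new, unique, unknown or untested is made for them only; others in the source may bear on it.

Compound 1, `Oc1ccc(-c2nc3cc(C(F)(F)F)ccc3[nH]2)cc1`, is tested in an ADME assay on MT4 cells (Homo sapiens) for cytotoxicity, read by MTT assay, with a stated time of 96 h (a lower number here means that less compound is tolerated, a higher number that more compound is tolerated), where compound 1 gives 17000 nM. Among the compounds with values here, only one other number is recorded there: compound 2, `Cn1c(-c2ccc(N)cc2)nc2cc(C(F)(F)F)ccc21`, gives 20000 nM in this assay, and the two values lie within the scatter of each other, so neither stands apart. Compound 3, `O=C(CCl)Nc1ccc(-c2nc3cc(C(F)(F)F)ccc3[nH]2)cc1`, differs from compound 1 by ((chloromethyl)carbonyl)amino in place of hydroxy on an aromatic carbon. Within the data shown here, no measured pair shows this change, so no measured step is available. For compound 3 a modest downward move in this assay is expected, with a 2.1-fold lower number from compound 1 to compound 3 (0.33 log units; beyond the scatter) estimated as the step. Compound 3 is thus estimated at 8000 nM, ranging from 2500 nM to 25000 nM.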

Compound 3, half-maximal cytotoxic concentration: 5000 nM
Estimate against measurement, compound 3: 1.6-fold (0.20 log units) above; the measured number falls inside the stated range.
By their numbers in this assay, from the lowest: compound 3; then compounds 1 and 2 (each within the scatter of the next).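

Within the data shown here, this is the first measured step at this position: with ((chloromethyl)carbonyl)amino in place of hydroxy on the aromatic carbon, this assay shows a 3.4-fold lower number from compound 1 to compound 3 (0.53 log units; beyond the scatter). The group at this position can therefore move the number beyond the scatter, towards less compound tolerated. Nothing available explains this step. The compounds shown leave open whether the step belongs to the chlorine or to the amide as a whole. An acetylamino group or a free amine on that carbon would separate the two.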